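The source may hold more compounds than are shown below. What is called first, only, known or untested is meant among the compounds shown, and "the series" means these compounds.

Compound 1 `COc1ccc(-c2cnc3nc(N)nc(N4CCN(Cc5ccc(C(C)(C)C)cc5)CC4)c3n2)cc1OC`: 4300 nM
Compound 2 `COc1ccc(-c2cnc3nc(N)nc(N4CCN(C(=O)CCc5ccccc5)CC4)c3n2)cc1OC`: 100 nM

For the measured compounds named here, in a functional assay on cells (T-cell, Homo sapiens) for inhibition (a higher number here means a weaker inhibitor, a lower number a stronger inhibitor), compound 2 stands lowest of the two numbers; the only neighbour, compound 1, gave 4300 nM. Going by the values given here, the single measured step, a 43-fold lower number from compound 1 to compound 2 (1.63 log units; beyond the scatter), came with phenethylcarbonyl in place of 4-(tert-butyl)benzyl on an amine nitrogen in a ring. Compound 3 `COc1ccc(-c2cnc3nc(N)nc(N4CCN(C(=O)Nc5ccccc5)CC4)c3n2)cc1OC` keeps that carbonyl and differs from compound 2 by anilino in place of phenethyl on a carbonyl carbon. Among the compounds with values here, no measured step tests this exchange, and the large step into compound 2 does not carry over to it, so only a small step, expected as a 1.5-fold higher number from compound 2 to compound 3 (0.18 log units; within the scatter), is foreseen in this assay. Compound 3 is therefore estimated at 150 nM, within 40 nM to 600 nM.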

Compound 3, half-maximal inhibitory concentration: 3.4 nM
The estimate for compound 3 lay 44-fold (1.64 log units) above the measured number; measured number outside the range, below it.
By their numbers in this assay, from the lowest: compound 3; then compound 2; then compound 1.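

In this assay, the group on the carbonyl carbon proves decisive: anilino in place of phenethyl gives a 29-fold lower number from compound 2 to compound 3 (1.47 log units; beyond the scatter) even though both groups hold one six-membered aromatic ring, and the entering group adds one hydrogen-bond donor. Keeping a carbonyl is therefore not enough to set the level, and the full change to phenylcarbamoyl gives a 1300-fold lower number from compound 1 to compound 3 (3.10 log units; beyond the scatter) on the same ring nitrogen. Nothing available explains why this exchange has so large an effect.

Open, on these data alone, is whether the hydrogen on the anilino nitrogen matters, which a methylated anilino nitrogen would test. Also open, as far as these compounds go, is how a benzylamino group, or a methoxy group on the phenyl ring, would compare.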